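The source may report more compounds than this note shows. Statements on the series, on what has been measured and on what is new or still open speak of the compounds shown alone.

Measured so far:
compound 1 `FC(F)(F)c1cccc(-c2nc3cnc(Nc4ccncn4)cc3[nH]2)c1` — < 5000 nM in this assay
compound 2 `Fc1ccc(-c2nc3cnc(Nc4ccccn4)cc3[nH]2)cc1F` — < 5000 nM in this assay

In a physicochemical assay for solubility, using the shake flask method, in phosphate buffer, measured as kinetic solubility, with a stated time of 20 h, at pH 6.5 (on this read-out higher numbers stand for higher solubility and lower numbers for lower solubility), compound 1 gives < 5000 nM, a limit of the assay rather than a number. Compound 2 gives < 5000 nM in this assay, again a limit. (the limit of < 5000 nM in this assay, at which 2 of the 2 values shown sit), so compound 1 cannot be placed above or below compound 2 on the numbers shown, and no step between measured compounds can be read off.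

Compound 3 `O=C(O)c1ccc(Nc2cc3[nH]c(-c4cccc(C(F)(F)F)c4)nc3cn2)nc1` has not yet been measured. It differs from compound 1 in one place: 5-carboxypyridin-2-yl in place of pyrimidin-4-yl on a nitrogen on an aromatic ring. Going by the values given here, with both measured values sitting at a limit, there is no measured step to lean on. For the move from compound 1 to compound 3 an upward step beyond the usual scatter is expected, estimated as an at least 10-fold higher number from compound 1 to compound 3 (1.00 log units; beyond the scatter). Compound 3 is therefore estimated at 50000 nM in this assay, with a range from 5000 nM to 400000 nM.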

Compound 3, solubility: 6000 nM
For compound 3 the middle estimate is 8.3-fold (0.92 log units) above the measured one, within the range that was stated.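

In this assay, going by these compounds alone, compound 3 gives 6000 nM, the only value shown that is a number rather than a limit. Putting 5-carboxypyridin-2-yl in place of pyrimidin-4-yl on a nitrogen on an aromatic ring gives an at least 1.2-fold higher number from compound 1 to compound 3 (0.07 log units; that floor lies within the scatter). This step is only a floor and does not establish a real change, because the reading for compound 1 is not a number: the limit of < 5000 nM in this assay, at which 2 of the 3 values shown sit.

The change swaps the ring and brings in the carboxylic acid in a single move, and the compounds shown do not separate the two contributions. From the compounds shown here alone, how a methyl ester, a primary amide or an amine in place of the carboxylic acid would read in this assay remains open, as does the true distance between compound 1 and compound 3.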